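This account rests on a few compounds, and the source may have more. Where it says the series, first, only, none or still open, it means among the compounds named here.

Measured compounds:
Compound 1 `CCNC(=O)C1=C(C)NC(=O)NC1c1ccoc1`: 2%
Compound 2 `CCNC(=O)C1=C(C)NC(=O)NC1c1ccsc1`: 1%

In an assay on membranes from HEK293 cells for displacement of a labelled ligand from adenosine receptor A2b (Homo sapiens), read by scintillation counting, with a stated time of 30 min, tested at 1 uM (a higher number here means more inhibition at the concentration tested (going by the name of the read-out), a lower number less inhibition), compound 1 gives 2%, and compound 2 gives 1%. Of the two numbers, compound 1 holds the higher one, but the step of a number 1 percentage points lower from compound 1 to compound 2 (within the scatter) lies within the scatter, so the two compounds cannot be told apart on this read-out; both show almost no inhibition.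

Compound 3 `CC1=C(C(=O)OC2CCCCC2)C(c2ccoc2)NC(=O)N1` differs from compound 1 in one place: cyclohexyloxy in place of ethylamino on a carbonyl carbon. For the measured compounds named here, no measured step bears on this change. Going by the values given here, the only step available, a number 1 percentage points lower from compound 1 to compound 2 (within the scatter), concerns the ring on the saturated ring carbon and leaves the carbonyl carbon untouched, so it gives no guidance here. With compound 1 at 2% and nothing to point to a rise, compound 3 is expected to stay near the bottom of the scale, and the expected step of a number 2 percentage points higher from compound 1 to compound 3 (within the scatter) is not beyond the scatter. The estimate for compound 3 in this assay is 4%, with a range from -6% to 22%.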

Compound 3, a percentage reported as inhibition, at one concentration (the size of the read-out at that concentration, not a potency): 4%
Beside the measured number, compound 3's estimate shows no gap at the digits printed; the range from low to high includes it.
By their numbers in this assay, from the lowest: compounds 2, 1 and 3 (each within the scatter of the next).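

On the carbonyl carbon, cyclohexyloxy in place of ethylamino gives a number 2 percentage points higher from compound 1 to compound 3 (within the scatter) in this assay and so shows no measurable effect at this position, which the earlier pair left unvaried. Neither the larger group with its six-membered ring of carbon only nor the loss of the ethylamino hydrogen-bond donor separates compound 3 from compound 1, and both show almost no inhibition. No evidence is available to explain this flat result.

On these data alone, it remains open whether any other group on this carbonyl carbon, such as benzylamino, methoxy or the free carboxylic acid, would give real inhibition. As far as these compounds go, it is also open whether cyclohexyloxy would read the same with thiophen-3-yl in place of furan-3-yl on the saturated ring carbon.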